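The source may hold more compounds than are shown below. What is called first, only, known or untested is meant among the compounds shown, and "the series" means these compounds.

Measured compounds:
compound 1, `COCCNC(=O)c1ccc2c(c1)[n+]([O-])c(O)c(C#N)[n+]2[O-]`, > 16 ug/mL
compound 2, `CCNc1n[n+]([O-])c2ccccc2[n+]1[O-]`, 17 ug/mL

In an ADME assay on Vero cells (Chlorocebus sabaeus) for cytotoxicity, read by CellTiter-Glo, with a stated time of 72 h (a higher number here means that more compound is tolerated, a lower number that less compound is tolerated), compound 1 gives > 16 ug/mL, which is a limit of the assay rather than a number. Going by the values given here, compound 2 gives 17 ug/mL in this assay, and this is the only plain number among the two values shown, so compound 2 serves as the single reference point, the other compound resting at the limit of > 16 ug/mL in this assay, at which 1 of the 2 values shown sits.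

Compound 3, `[O-][n+]1nc(NC2CCC2)[n+]([O-])c2ccccc21`, has not yet been measured. It differs from compound 2 in one place: cyclobutyl in place of ethyl on a nitrogen on an aromatic ring. Among the compounds with values here, no step between two measured compounds is available, so nothing measured shows what this exchange does in this assay. With compound 2 at 17 ug/mL as the only anchor, the expectation is a small move, if any, not clearly beyond the scatter, and the step from compound 2 to compound 3 is expected to be a 1.2-fold lower number from compound 2 to compound 3 (0.08 log units; within the scatter). Compound 3 is therefore expected to give 14 ug/mL in this assay, within a range from 7 ug/mL to 28 ug/mL.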

Compound 3, half-maximal cytotoxic concentration: 8.9 ug/mL
Beside the measured number, compound 3's estimate is 1.6-fold (0.20 log units) above it, and the stated range covers the measured number.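

Going by these compounds alone, this is the first measured step at this position: cyclobutyl in place of ethyl on a nitrogen on an aromatic ring gives a 1.9-fold lower number from compound 2 to compound 3 (0.28 log units; within the scatter) in this assay. The exchange brings in a four-membered ring of carbon where ethyl has no ring, yet these two compounds cannot be told apart in this cell test, so this one change shows no clear effect on how much compound the cells tolerate. Compound 1 stays out of this comparison, since it differs from the others in more than one place and its value is a limit of the assay rather than a number: the limit of > 16 ug/mL in this assay, at which 1 of the 3 values shown sits.

Going by these compounds, what the other groups on this nitrogen would do stays open, whether a longer chain such as butyl, a chain ending in an amine, or one ending in a carboxylic acid. A single step within the scatter also cannot show whether any change at this position moves the result clearly, or whether the exchange from ethylamino to cyclobutylamino would read the same on a differently substituted core.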